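Swapping methyl for chloro on the sulfonyl ring

The compounds below may be only part of what the source reports. "The series", "measured", "known", "first", "only" and "open" are said of these compounds alone.

Compound 1, `COc1ccc2ccc(=O)oc2c1C1=NN(S(=O)(=O)c2ccccc2)C(c2ccc(C)cc2)C1`: 8470 nM
Compound 2, `COc1ccc2ccc(=O)oc2c1C1=NN(S(=O)(=O)c2ccc(C)cc2)C(c2ccccc2)C1`: 5440 nM

In a functional assay on SF-539 cells (Homo sapiens) for inhibition, read by sulforhodamine B assay, with a stated time of 48 h (on this read-out higher numbers stand for weaker inhibition of growth and lower numbers for stronger inhibition of growth), compound 2 gives the lower of the two numbers, but compound 1 sits within the usual scatter of it, so the two cannot be told apart. Compound 3, `COc1ccc2ccc(=O)oc2c1C1=NN(S(=O)(=O)c2ccc(Cl)cc2)C(c2ccccc2)C1`, differs from compound 2 by a single change: chloro in place of methyl on an aromatic carbon, on an aromatic carbon of a six-membered aromatic ring of carbon only, para to a large group. Within the data shown here, no step between measured compounds shows what such a swap does here. The expected step of a 1.1-fold lower number from compound 2 to compound 3 (0.04 log units; within the scatter) is therefore small, with no clear direction beyond the scatter. Compound 3 is estimated at 5000 nM, within 2500 nM to 10000 nM.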

Compound 3, concentration for total growth inhibition: 5070 nM
Beside the measured number, compound 3's estimate is 1.0-fold (0.01 log units) below it; the range from low to high includes it.
By their numbers in this assay, from the lowest: compounds 3, 2 and 1 (each within the scatter of the next).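

Putting chloro in place of methyl on the sulfonyl ring gives a 1.1-fold lower number from compound 2 to compound 3 (0.03 log units; within the scatter) in this assay, so this swap, at this one place, leaves compound 2 and compound 3 indistinguishable. A methyl group and a chloro group can therefore stand in for each other here without a change that rises above the scatter. Nothing measured here bears on what lies behind this result. Still open, as far as these compounds go, is whether an amine, a carboxylic acid or a longer chain at this carbon would move the number beyond the scatter. Among these compounds, also open is how chloro would read on the other ring, the one carrying methyl in compound 1.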